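The source may report more compounds than this note shows. Statements on the series, on what has been measured and on what is new or still open speak of the compounds shown alone.

Values in a functional assay on MCF7 cells (Homo sapiens) for inhibition, read by MTT assay, with a stated time of 72 h (on this read-out higher numbers stand for weaker inhibition and lower numbers for stronger inhibition), for the measured compounds:

compound 1 `COc1ccc(-n2cc(C(=O)Nc3ccc(Oc4ccnc5[nH]ccc45)cc3)c(=O)c3ccccc32)cc1`: 4650 nM
compound 2 `Cn1ccc2c(Oc3ccc(NC(=O)c4cn(-c5ccccc5)c5ccccc5c4=O)cc3F)ccnc21`: 2790 nM
compound 3 `Cn1ccc2c(Oc3ccc(NC(=O)c4cn(-c5ccc(Cl)cc5)c5ccccc5c4=O)cc3F)ccnc21`: 2120 nM

Compound 3 gives the lowest number of the three in this assay, but the step of a 1.3-fold lower number from compound 2 to compound 3 (0.12 log units; within the scatter) lies within the scatter, so compounds 2 and 3 cannot be ordered; only compound 1, at 4650 nM, stands apart from compound 3 beyond the scatter.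

Compound 4 `Cn1ccc2c(Oc3ccc(NC(=O)c4cn(-c5ccc(Br)cc5F)c5ccccc5c4=O)cc3F)ccnc21` differs from compound 3 by 4-bromo-2-fluorophenyl in place of 4-chlorophenyl on an aromatic nitrogen. Going by the values given here, the only measured step touching this phenyl is a 1.3-fold lower number from compound 2 to compound 3 (0.12 log units; within the scatter), a halogen exchange on an aromatic carbon that stayed within the scatter. On that basis the further halogen change is expected to move the number little, with the step from compound 3 to compound 4 estimated as a 1.1-fold lower number from compound 3 to compound 4 (0.03 log units; within the scatter) in this assay. Compound 4 is accordingly expected to give about 2000 nM, within 900 nM to 4500 nM.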

Compound 4, half-maximal inhibitory concentration: 420 nM
Beside the measured number, compound 4's estimate is 4.8-fold (0.68 log units) above it; measured number outside the range, below it.
By their numbers in this assay, from the lowest: compound 4; then compounds 3, 2 and 1 (each within the scatter of the next, the first and the last beyond it).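

The phenyl on the aromatic nitrogen does respond in this assay: a 5.0-fold lower number from compound 3 to compound 4 (0.70 log units; beyond the scatter) is beyond the scatter and so is a 6.6-fold lower number from compound 2 to compound 4 (0.82 log units; beyond the scatter) while the earlier chloro step a 1.3-fold lower number from compound 2 to compound 3 (0.12 log units; within the scatter) stayed within it. The entering 4-bromo-2-fluorophenyl changes this position in two ways at once, with bromine in place of chlorine and an added fluorine.

Going by these compounds alone, still open are whether the bromine, the fluorine or only the pair carries the step, and how an amine or a nitrile on this phenyl would read. Nothing available accounts for the size of the step.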